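Trimming the Aryl Urea Down to a Plain Benzamide

The compounds below may be only part of what the source reports. "The series", "measured", "known", "first", "only" and "open" are said of these compounds alone.

Measured so far:
Compound 1, `COc1cc(-c2nn(-c3cccc(NC(=O)Nc4ccc(Cl)c(Cl)c4)c3)cc2-c2ccncc2)ccc1Cl`: 151 nM
Compound 2, `COc1cc(-c2nn(-c3cccc(NC(=O)c4ccc(Cl)c(C(F)(F)F)c4)c3)cc2-c2ccncc2)ccc1Cl`: 665 nM
Compound 3, `COc1cc(-c2nn(-c3cccc(NC(=O)Nc4ccc(Cl)c(C(F)(F)F)c4)c3)cc2-c2ccncc2)ccc1Cl`: 499 nM

These three compounds share a core and differ only in the group hanging from the carbonyl of the side-chain amide. In a functional assay on HOP-92 cells (Homo sapiens) for inhibition, read by sulforhodamine B assay, with a stated time of 48 h (on this read-out lower numbers stand for stronger inhibition of growth and higher numbers for weaker inhibition of growth), compound 3 gives 499 nM, the second highest of the three numbers; it sits close to compound 2 and clearly apart from compound 1, as shown by a 3.3-fold higher number from compound 1 to compound 3 (0.52 log units; beyond the scatter).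

Compound 4, `COc1cc(-c2nn(-c3cccc(NC(=O)c4ccccc4)c3)cc2-c2ccncc2)ccc1Cl`, is not yet measured. It differs from compound 3 as follows: phenyl in place of (4-chloro-3-(trifluoromethyl)phenyl)amino on a carbonyl carbon. For the measured compounds named here, two measured steps bear on this change. The step of a 1.3-fold lower number from compound 2 to compound 3 (0.12 log units; within the scatter) shows that exchanging the urea for a direct aryl amide, with the same substituted ring, changes little. The step of a 3.3-fold higher number from compound 1 to compound 3 (0.52 log units; beyond the scatter) shows that altering one ring substituent already matters. Compound 4 removes the linking nitrogen and both ring substituents together, a larger change than either measured step, so a weaker result is expected, of about a 3.0-fold higher number from compound 3 to compound 4 (0.48 log units; beyond the scatter). For compound 4 a value of 1500 nM is expected, within a range from 500 nM to 5000 nM.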

Compound 4, concentration for 50% growth inhibition: 324 nM
Compound 4: middle estimate off by 4.6-fold (0.67 log units), on the high side; the measured number lies below the stated range.
By their numbers in this assay, from the lowest: compound 1; then compounds 4, 3 and 2 (each within the scatter of the next, the first and the last beyond it).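

In this assay, cutting this position down to a bare phenyl loses nothing that can be detected, since a 1.5-fold lower number from compound 3 to compound 4 (0.19 log units; within the scatter) shows that the (4-chloro-3-(trifluoromethyl)phenyl)amino group is not needed to keep this level of growth inhibition. On the direct amide, the plain ring even does modestly better than the ring carrying chloro and trifluoromethyl, with a 2.1-fold lower number from compound 2 to compound 4 (0.31 log units; beyond the scatter). Only the urea of compound 1 keeps a modest edge over the bare ring, as a 2.1-fold higher number from compound 1 to compound 4 (0.33 log units; beyond the scatter) shows, so a substituted urea can still outperform phenyl when its ring carries the right groups.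

Nothing measured here explains these differences. Going by these compounds, it also remains open whether a cyclohexyl ring in place of the phenyl, or an amine or a carboxylic acid on it, would hold this level of inhibition.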